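Hydroxymethyl on the Amide Nitrogen of an Adenosine Ligand

The source may hold more compounds than are shown below. What is called first, only, known or untested is meant among the compounds shown, and "the series" means these compounds.

Two compounds built on a shared core were tested in an assay on CHO cells for displacement of a labelled ligand from adenosine receptor A1 (Homo sapiens), read by scintillation counting, with a stated time of 90 min, tested at 1 uM; on this read-out lower numbers stand for less inhibition and higher numbers for more inhibition at the one concentration tested (going by the name of the read-out). Going by the values given here, compound 1 `N#Cc1c(N)nc(SCC(N)=O)c(C#N)c1-c1ccc(OCC2CC2)cc1` gives 31% in this assay, the higher of the two numbers known so far. Compound 2 `N#Cc1c(N)nc2sc(C(N)=O)c(N)c2c1-c1ccc(OCC2CC2)cc1` gives 19% in this assay, a gap from compound 1 that lies beyond the usual scatter. No pair among these two compounds differs in a single place, so no measured step is available to guide the next one.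

Compound 3 `N#Cc1c(N)nc(SCC(=O)NCO)c(C#N)c1-c1ccc(OCC2CC2)cc1` is compound 1 with one change: hydroxymethyl in place of hydrogen on an amide-type nitrogen. Nothing measured shows what such a change does here, so the expected step from compound 1 is modest, a number 4 percentage points lower from compound 1 to compound 3 (within the scatter), a small drop that need not exceed the scatter. On that basis compound 3 is estimated to give 27% in this assay, with a plausible range from 10% to 44%.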

Compound 3, a percentage reported as inhibition, at one concentration (the size of the read-out at that concentration, not a potency): 10%
The estimate for compound 3 lay 17 percentage points above the measured number; low and high end bracket the measured number.
By their numbers in this assay, from the lowest: compounds 3 and 2 (each within the scatter of the next); then compound 1.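

Hydroxymethyl in place of hydrogen on the amide-type nitrogen brings a number 21 percentage points lower from compound 1 to compound 3 (beyond the scatter) in this assay, the only single-place step among the compounds shown. This nitrogen is therefore a place where even a small addition of 2 heavy atoms can move the number, and here the hydrogen gives more inhibition than hydroxymethyl. Nothing available explains why the number falls with this change.

The compounds shown do not tell whether the fall belongs to the hydroxyl of hydroxymethyl or would follow any group placed on this nitrogen. A methyl group or a longer chain such as 2-hydroxyethyl on the same nitrogen could separate these two readings, and a carboxylic acid in place of the carbamoyl group would test whether the amide is needed at all.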